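The source may hold more compounds than are shown below. What is called first, only, known or untested is meant among the compounds shown, and "the series" means these compounds.

Compound 1 `Cc1cc(NC(=O)Nc2ncccc2C)c2ccccc2n1`, compound 2 `Cc1cc(NC(=O)Nc2cccc(OC(F)(F)F)c2)c2ccccc2n1` and compound 3 `Cc1cc(NC(=O)Nc2cc(F)cc(F)c2)c2ccccc2n1` share one core and differ only in the ring on the far side of the urea.

In an ADME assay on HepG2 cells (Homo sapiens) for cytotoxicity, with a stated time of 72 h (on this read-out lower numbers stand for an effect already at smaller amounts and higher numbers for an effect only at larger amounts of compound), compound 1 shows only a limit of the assay, > 25000 nM. In this assay compound 2 gives 13000 nM. For compound 3, this assay again reports only a limit, > 25000 nM. Compound 3 therefore stands at the limit of > 25000 nM in this assay, at which 2 of the 3 values shown sit, without a number of its own.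

Compound 4 `Cc1cc(NC(=O)Nc2cccc(F)c2)c2ccccc2n1` differs from compound 3 in one place: hydrogen in place of fluoro on an aromatic carbon. Among the compounds with values here, no measured pair shows this change. The expected step of a number no higher from compound 3 to compound 4 (the limit leaves the size open) in this assay stays within the scatter, with no clear direction. Compound 4 is estimated at 25000 nM, within a range from 10000 nM to 60000 nM.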

Compound 4, half-maximal effective concentration: > 25000 nM
Compound 4 was reported as a limit; the forecaster's own chance of this, stated with the estimate: 60%; the middle value lies on the limit itself.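

With one fluoro fewer on the ring, compound 4 is still reported in this assay only as a limit (> 25000 nM). Within the data shown here, its steps from compound 1 and compound 3 cannot be read, since both ends are limits, and the one readable step is an at least 1.9-fold higher number from compound 2 to compound 4 (0.28 log units; that floor lies within the scatter) for fluoro in place of trifluoromethoxy. So the ring with a single fluoro sits with the ring carrying two, at the same limit: the limit of > 25000 nM in this assay, at which 3 of the 4 values shown sit.

From the compounds shown here alone, how far compound 3 and compound 4 truly lie beyond that limit stays open. So does what an amine or a carboxylic acid at this position would give.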